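This account rests on a few compounds, and the source may have more. Where it says the series, first, only, none or still open, it means among the compounds named here.

In a functional assay on A-431 cells (Homo sapiens) for inhibition, read by MTT assay, with a stated time of 72 h (on this read-out lower numbers stand for stronger inhibition and higher numbers for weaker inhibition), compound 1 `COc1ccc(-c2nnc(SCCCN3CCN(c4nc5ccccc5s4)CC3)o2)cc1` gives 56200 nM and compound 2 `O=[N+]([O-])c1ccc(-c2nnc(SCCCN3CCN(c4nc5ccccc5s4)CC3)o2)cc1` gives 46500 nM so the two stand level within the scatter. Compound 3 `Cc1ccc(-c2nnc(SCCCN3CCN(c4nc5ccccc5s4)CC3)o2)cc1` is not yet measured and differs from compound 2 by methyl in place of nitro on an aromatic carbon. Going by the values given here, the one measured step at this place is a 1.2-fold lower number from compound 1 to compound 2 (0.08 log units; within the scatter) and it stays within the scatter, so it gives no sign of a larger change. No step beyond the scatter is expected in this assay for the methyl compound. The expected step is a 1.1-fold higher number from compound 2 to compound 3 (0.03 log units; within the scatter) and it lies within the scatter. Compound 3 is estimated at 50000 nM with an expected range (24000 nM to 100000 nM).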

Compound 3, half-maximal inhibitory concentration: 61600 nM
The estimate for compound 3 lay 1.2-fold (0.09 log units) below the measured number; low and high end bracket the measured number.
By their numbers in this assay, from the lowest: compounds 2, 1 and 3 (each within the scatter of the next).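

Methyl now joins nitro and methoxy on this aromatic carbon, para to a large group, and the three compounds stand level in this assay: the steps are a 1.3-fold higher number from compound 2 to compound 3 (0.12 log units; within the scatter) and a 1.1-fold higher number from compound 1 to compound 3 (0.04 log units; within the scatter). The 4-nitrophenyl to 4-methylphenyl change therefore shows no step beyond the scatter, and neither does the change from methoxy to methyl. No measurement at hand accounts for this level reading.

As far as these compounds go, whether an amine or a carboxylic acid at this place would also stand level remains open. From the compounds shown here alone, the effect of changes elsewhere on the shared core also remains open.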